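The source may hold more compounds than are shown below. What is called first, only, known or untested is meant among the compounds shown, and "the series" means these compounds.

Compound 3 `COc1cc(-c2c(C)nn(C)c2C)ccc1-c1nnc(N(C)Cc2ccc3nccn3c2)o1` gives 15.9 nM in an assay on isolated protein for inhibition of tyrosine-protein kinase Mer (Homo sapiens), read by LC-MS; a lower number here means a stronger inhibitor, a higher number a weaker inhibitor. Compound 1 `Cc1nn(C)c(C)c1-c1ccc(-c2nnc(N(C)Cc3ccc4nccn4c3)o2)cc1` gives 31.6 nM and compound 2 `Cc1nn(C)c(C)c1-c1ccc(-c2nnc(N(C)Cc3ccc4nccn4c3)o2)c(F)c1` gives 12.6 nM; compound 3 lies within the usual scatter of both. Compound 4 `Cc1cc(-c2c(C)nn(C)c2C)ccc1-c1nnc(N(C)Cc2ccc3nccn3c2)o1` carries methyl in place of methoxy on an aromatic carbon. For the measured compounds named here, the steps that touch this position are a 2.0-fold lower number from compound 1 to compound 3 (0.30 log units; within the scatter) and a 1.3-fold higher number from compound 2 to compound 3 (0.10 log units; within the scatter), both within the scatter, so hydrogen, fluoro and methoxy at this carbon have not separated the numbers; the only change beyond the scatter is a 2.5-fold lower number from compound 1 to compound 2 (0.40 log units; beyond the scatter). Going by the values given here, no direct precedent for methyl at this position exists. The expected step is a 1.0-fold higher number from compound 3 to compound 4 (0.00 log units; within the scatter), none beyond the scatter. Compound 4 is estimated at 16 nM, with a range from 7 nM to 36 nM.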

Compound 4, half-maximal inhibitory concentration: 3.16 nM
For compound 4 the middle estimate is 5.1-fold (0.70 log units) above the measured one; measured number below the stated range.
By their numbers in this assay, from the lowest: compound 4; then compounds 2, 3 and 1 (each within the scatter of the next, the first and the last beyond it).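

Methyl is the first group at this carbon to set a compound clearly apart from all the others, with a 5.0-fold lower number from compound 3 to compound 4 (0.70 log units; beyond the scatter) and a 4.0-fold lower number from compound 2 to compound 4 (0.60 log units; beyond the scatter) and a 10-fold lower number from compound 1 to compound 4 (1.00 log units; beyond the scatter) as its steps. Among hydrogen, fluoro and methoxy, only the change from hydrogen to fluoro passed the scatter, so the gain with methyl is not shared by the other two substituents. No available measurement accounts for this gain.

As far as these compounds go, whether ethyl or chloro at this carbon would match methyl remains open. So does whether methyl keeps its gain with another group in place of the 1,3,5-trimethyl-1H-pyrazol-4-yl group.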